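The compounds below may be only part of what the source reports. "The series", "measured", "known", "first", "only" and "open" are said of these compounds alone.

Measured so far:
- compound 1, `COCCNc1nc(C)nc2c1nnn2-c1c(C)cc(C)cc1C`: 1200 nM
- compound 2, `COCC(C)(C)Nc1nc(C)nc2c1nnn2-c1ccc(C(C)C)cc1Br`: 195 nM
- compound 3, `CCCCN(CC)c1nc(C)nc2c1nnn2-c1ccc(S(C)(=O)=O)cc1Br`: 100 nM

In an in vitro assay on 293-EBNA cells for binding affinity to corticotropin-releasing factor receptor 1 (Homo sapiens) (a higher number here means a weaker inhibitor, a lower number a stronger inhibitor), compound 1 gives 1200 nM, compound 2 gives 195 nM and compound 3 gives 100 nM. Compound 2 holds the second highest of the three numbers. Its nearest neighbour is compound 3, whose number is lower but only by an amount that lies within the scatter, so the two cannot be ranked against each other. Compound 1 is the furthest away, with a number higher by a margin beyond the scatter. Among the measured compounds shown here, no pair among the measured compounds differs in a single place, so no measured step is available to anchor what follows.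

The unmeasured compound 4, `CCC(CO)Nc1nc(C)nc2c1nnn2-c1ccc(C(C)C)cc1Br`, is reached from compound 2 by the change (1-(hydroxymethyl)propyl in place of 1-(methoxymethyl)-1-methylethyl on a nitrogen on an aromatic ring). The methyl ether gives way to a free hydroxyl, one hydrogen-bond donor enters, and the branching at the carbon attached to the nitrogen changes from a quaternary to a tertiary pattern. For the measured compounds named here, no measured step shows what such a change does, so the expectation rests on the numbers of compound 2 alone. A modest step, in either direction, is all that is expected, most likely not beyond the scatter. The step expected is a 1.5-fold lower number from compound 2 to compound 4 (0.18 log units; within the scatter). Compound 4 is therefore estimated at 130 nM, with a range from 40 nM to 450 nM in this assay.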

Compound 4, inhibition constant: 25.3 nM
The estimate for compound 4 lay 5.1-fold (0.71 log units) above the measured number; the measured number lies below the stated range.
By their numbers in this assay, from the lowest: compound 4; then compounds 3 and 2 (each within the scatter of the next); then compound 1.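

In this assay, among the compounds shown here, 1-(hydroxymethyl)propyl in place of 1-(methoxymethyl)-1-methylethyl on a nitrogen on an aromatic ring gives a 7.7-fold lower number from compound 2 to compound 4 (0.89 log units; beyond the scatter) and stands as the only single-place step. For the compounds shown here, with the rest of the structure held constant, the read-out therefore responds to this nitrogen substituent by more than the scatter, which the earlier compounds, all differing in more than one place, could not show. The change is composite, with 5 heavy atoms entering against 6 leaving and 1 hydrogen-bond donor entering against 0 leaving, and no supporting data assign the step to any one of these differences.

Separating these differences needs 1-(methoxymethyl)propyl, which keeps the ether on the new branching, and 1-(hydroxymethyl)-1-methylethyl, which keeps the hydroxyl on the old branching. Also open, going by these compounds, are whether the step carries over to the other groups on the shared core, such as those of compound 1, and how an amine or a carboxylic acid would read in place of the hydroxyl.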